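Phenyl in Place of (Methoxycarbonyl)amino: An Expected Outcome

This account rests on a few compounds, and the source may have more. Where it says the series, first, only, none or still open, it means among the compounds named here.

Compound 1 `Cc1nc2cnccc2n1CC1CCN(C(=O)CNC(c2ccccc2)c2ccccc2)CC1`: 0.067 mg/kg
Compound 2 `COC(=O)NC(CC(=O)N1CCC(Cn2c(C)nc3cnccc32)CC1)c1ccccc1`: 0.035 mg/kg
Compound 3 `Cc1nc2cnccc2n1CC1CCN(C(=O)CCc2ccccc2)CC1`: limit > 5 mg/kg

In a functional assay on the whole organism (arterial blood) with Rattus norvegicus as the target (on this read-out higher numbers stand for an effect only at larger amounts of compound and lower numbers for an effect already at smaller amounts), compound 2 gives 0.035 mg/kg, the lowest of the two numbers shown. Compound 1 gives 0.067 mg/kg, which lies within the scatter of that. Compound 3 reaches only the assay limit > 5 mg/kg. Compound 4 `Cc1nc2cnccc2n1CC1CCN(C(=O)CC(c2ccccc2)c2ccccc2)CC1` differs from compound 2 by phenyl in place of (methoxycarbonyl)amino on a saturated chain carbon bound to an aromatic carbon and a saturated chain carbon. For the measured compounds named here, the one measured step at this place, an at least 140-fold higher number from compound 2 to compound 3 (2.15 log units; beyond the scatter), shows that stripping the (methoxycarbonyl)amino to hydrogen loses activity, ending at the limit of > 5 mg/kg in this assay, at which 1 of the 3 values shown sits. Compound 4 keeps a group at that place, and compound 1, carrying two phenyl groups, gives 0.067 mg/kg. Compound 4 is therefore expected to show only a modest rise, a 4.3-fold higher number from compound 2 to compound 4 (0.63 log units; beyond the scatter), estimated at 0.15 mg/kg (range 0.04 mg/kg to 0.8 mg/kg).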

Compound 4, dose for 50% inhibition: 0.0086 mg/kg
The estimate for compound 4 lay 17-fold (1.24 log units) above the measured number; the measured number lies below the stated range.
By their numbers in this assay, from the lowest: compound 4; then compounds 2 and 1 (each within the scatter of the next). At a limit, above all of these: compound 3.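

In this assay phenyl does more than replace (methoxycarbonyl)amino on this saturated chain carbon (a 4.1-fold lower number from compound 2 to compound 4 (0.61 log units; beyond the scatter)). A group of carbon only, with no hydrogen-bond donor or acceptor, is therefore enough at this place, and set against hydrogen it gives a far larger difference (an at least 580-fold lower number from compound 3 to compound 4 (2.76 log units; beyond the scatter)). The size of that second step is only a lower bound, as compound 3 stands at a limit and not at a number: the limit of > 5 mg/kg in this assay, at which 1 of the 4 values shown sits.

Open, as far as these compounds go, is how methyl, an amine or a carboxylic acid on this carbon would compare with phenyl.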